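The source may report more compounds than this note shows. Statements on the series, on what has been measured and on what is new or still open speak of the compounds shown alone.

In a functional assay on MCF7 cells (Homo sapiens) for cytotoxicity, read by MTT assay, with a stated time of 72 h (a lower number here means a stronger inhibitor, a higher number a weaker inhibitor), compound 1 (`COc1ccc(/C=C2\CCC/C(=C\c3ccc(Br)cc3)C2=O)cc1OC`) gives 6900 nM and compound 2 (`COc1ccc(/C=C2\CCC/C(=C\c3ccc(O)c(Cl)c3)C2=O)cc1OC`) gives 12300 nM. Compound 2 therefore stands level with compound 1 within the scatter, and no order can be read between them. Compound 3 (`COc1ccc(/C=C2\CCC/C(=C\c3ccc(O)c(O)c3)C2=O)cc1OC`) follows from compound 2 through hydroxy in place of chloro on an aromatic carbon, ortho to a hydroxy group, so that 3-chloro-4-hydroxyphenyl becomes 3,4-dihydroxyphenyl. Among the measured compounds shown here, the only measured step touching this aryl group, a 1.8-fold higher number from compound 1 to compound 2 (0.25 log units; within the scatter), is small, and it exchanges the whole group. For the measured compounds named here, no measured step isolates chloro against hydroxy. A step beyond the scatter is therefore not expected in this assay, and no direction is favoured. The expected step is a 1.1-fold lower number from compound 2 to compound 3 (0.05 log units; within the scatter). For compound 3 the estimated value is 11000 nM, with an expected range from 4500 nM to 27000 nM.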

Compound 3, half-maximal inhibitory concentration: 14400 nM
Beside the measured number, compound 3's estimate is 1.3-fold (0.12 log units) below it, and the stated range covers the measured number.
By their numbers in this assay, from the lowest: compounds 1, 2 and 3 (each within the scatter of the next, the first and the last beyond it).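

In this assay the exchange of chloro for hydroxy, on an aromatic carbon ortho to a hydroxy group, is now isolated: a 1.2-fold higher number from compound 2 to compound 3 (0.07 log units; within the scatter) gives no order between 3-chloro-4-hydroxyphenyl and 3,4-dihydroxyphenyl. Among the compounds shown here, the wider exchange of the whole aryl group, a 2.1-fold higher number from compound 1 to compound 3 (0.32 log units; beyond the scatter), is the only step so far printed as beyond the scatter; it is modest, and with compound 2 within the scatter of both neighbours it cannot be assigned to any single substituent. No measurement in hand explains either step.

Still open, from the compounds shown here alone, is whether an amine or a carboxylic acid on this aromatic carbon would give a step beyond the scatter. Also open, going by these compounds, is whether the bromo position alone carries the gap between compound 1 and compound 3.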